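Working notes: amine groups on a thiocarbonyl carbon

The source may report more compounds than this note shows. Statements on the series, on what has been measured and on what is new or still open speak of the compounds shown alone.

Measured in a functional assay on DU-145 cells (Homo sapiens) for cytotoxicity, read by MTT assay, with a stated time of 72 h; a higher number here means a weaker inhibitor, a lower number a stronger inhibitor:
- compound 1 `CCCCNC(=S)N/N=C1\CC(c2ccc(O)cc2)Oc2cc(O)ccc21` gives 57700 nM
- compound 2 `CCCN(CCC)C(=S)N/N=C1\CC(c2ccc(O)cc2)Oc2cc(O)ccc21` gives 62100 nM

On these numbers, compound 2 (62100 nM) stands within the scatter of compound 1 (57700 nM), so the two do not separate. Compound 3 `Oc1ccc(C2C/C(=N\NC(=S)N3CCCCC3)c3ccc(O)cc3O2)cc1` remains unmeasured. Its difference from compound 2 is piperidin-1-yl in place of dipropylamino on a thiocarbonyl carbon. Within the data shown here, one measured step bears on this place: a 1.1-fold higher number from compound 1 to compound 2 (0.03 log units; within the scatter), with dipropylamino in place of butylamino, and it stays within the scatter. Among the measured compounds shown here, no measured compound carries a ring there, so the evidence is thin. The change expected in this assay is therefore none beyond the scatter, with no direction favoured. The estimated step is a 1.1-fold lower number from compound 2 to compound 3 (0.05 log units; within the scatter) (an expectation only). Compound 3 is estimated at 55000 nM (expected range 25000 nM to 100000 nM).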

Compound 3, half-maximal inhibitory concentration: 55300 nM
Compound 3: middle estimate off by 1.0-fold (0.00 log units), on the low side; the range from low to high includes it.
By their numbers in this assay, from the lowest: compounds 3, 1 and 2 (each within the scatter of the next).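

With piperidin-1-yl, a ring now stands on the thiocarbonyl carbon, and in this assay it does not separate from either open-chain group: a 1.1-fold lower number from compound 2 to compound 3 (0.05 log units; within the scatter) and a 1.0-fold lower number from compound 1 to compound 3 (0.02 log units; within the scatter). Butylamino, dipropylamino and piperidin-1-yl therefore form a single group of values at this place, and the presence of a six-membered non-aromatic ring brings no step beyond the scatter for these three compounds. No supporting data bear on why the values stay together.

All three groups shown are built only from carbon and the nitrogen on the thiocarbonyl carbon, so it stays open whether a morpholin-4-yl ring, a phenylamino group or a chain ending in a carboxylic acid would move the number beyond the scatter. From the compounds shown here alone, whether the same flat picture holds on other cell lines also stays open.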